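The source may hold more compounds than are shown below. What is called first, only, known or untested is meant among the compounds shown, and "the series" means these compounds.

Compound 1 `O=C1Nc2ccccc2/C1=C\C(=O)c1c[nH]c2ccccc12`: 2110 nM
Compound 2 `COc1ccc(C(=O)Nc2ccc3c(c2)/C(=C/Nc2cccc(N4CCN(C)CC4)c2)C(=O)N3)cc1`: 1780 nM

Among the measured compounds shown here, in a functional assay on HepG2 cells (Homo sapiens) for inhibition, read by sulforhodamine B assay, with a stated time of 3 days (a higher number here means a weaker inhibitor, a lower number a stronger inhibitor), compound 2 gives 1780 nM and stands within the scatter of compound 1, the only other measured compound, at 2110 nM. Neither can be ranked above the other. Compound 3 `CC(C)CC(=O)Nc1ccc2c(c1)/C(=C/Nc1cccc(N3CCN(C)CC3)c1)C(=O)N2` carries isobutyl in place of 4-methoxyphenyl on a carbonyl carbon. For the measured compounds named here, no measured pair differs in one place, so the data give no direct guide to this change. Going by the values given here, compound 1 at 2110 nM and compound 2 at 1780 nM show only that two compounds differing in more than one place can lie close together. A small move toward a weaker inhibitor in this assay is therefore expected, one not clearly beyond the scatter. The estimated change is a 1.3-fold higher number from compound 2 to compound 3 (0.13 log units; within the scatter). Compound 3 is expected at 2400 nM, with an estimated range from 800 nM to 7500 nM.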

Compound 3, half-maximal inhibitory concentration: 5070 nM
Beside the measured number, compound 3's estimate is 2.1-fold (0.32 log units) below it; measured number inside the range.
By their numbers in this assay, from the lowest: compounds 2 and 1 (each within the scatter of the next); then compound 3.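

In this assay, among the compounds shown here, isobutyl in place of 4-methoxyphenyl on a carbonyl carbon gives the first step that can be read at this position, a 2.8-fold higher number from compound 2 to compound 3 (0.45 log units; beyond the scatter), and this step lies beyond the scatter. The place on the shared core therefore responds to the group carried by this carbonyl carbon, and in this single pair the lower number belongs to the compound with the aromatic ring and the greater heavy-atom count. Nothing measured here gives a reason for the step.

The compounds shown leave open whether the ring, its methoxy group or the size of the group goes with the difference. An unsubstituted phenyl, a 4-chlorophenyl or a longer alkyl chain on the same carbonyl carbon would help to separate these readings.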